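From compound 2 to compound 4: adding cyano

The compounds below may be only part of what the source reports. "The series", "measured", "known", "first", "only" and "open" are said of these compounds alone.

In a functional assay on A549 cells (Homo sapiens) for inhibition, read by sulforhodamine B assay, with a stated time of 74 h (a higher number here means a weaker inhibitor, a lower number a stronger inhibitor), compound 1 `CS(=O)(=O)N1C(=O)COC12C=CC(=O)C=C2` gives > 10000 nM, which is a limit and not a number. Compound 2 `O=C1C=CC2(C=C1)OCC(=O)N2S(=O)(=O)c1ccccc1` gives > 10000 nM, also a limit. Compound 3 `O=C1C=CC2(C=C1)OCC(=O)N2S(=O)(=O)c1ccc([N+](=O)[O-])cc1` gives > 10000 nM, again a limit. Compound 2 therefore has no measured number, and neither of the other two compounds offers one for comparison.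

Compound 4 `N#Cc1cccc(S(=O)(=O)N2C(=O)COC23C=CC(=O)C=C3)c1` has cyano in place of hydrogen on an aromatic carbon of compound 2: cyano in place of hydrogen on an aromatic carbon.

Two measured changes bear on this. The closer in kind is a step that the two limits leave unreadable from compound 2 to compound 3, with nitro in place of hydrogen on an aromatic carbon. The other is a step that the two limits leave unreadable from compound 1 to compound 2, with phenyl in place of methyl on a sulfonyl sulfur. Neither gives a size to carry over. The whole record so far is the limit of > 10000 nM in this assay, at which 3 of the 3 values shown sit, so no step beyond the scatter is expected in this assay, and no direction can be assigned. The expected change is a step that the limit leaves unreadable from compound 2 to compound 4. A further limit is the most likely report. If a number is obtained, compound 4 is estimated at 15000 nM, with an expected range from 5000 nM to 50000 nM.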

Compound 4, half-maximal inhibitory concentration: 1910 nM
For compound 4 the middle estimate is 7.9-fold (0.90 log units) above the measured one; the whole stated range lies above it.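

In this assay, an at least 5.2-fold lower number from compound 2 to compound 4 (0.71 log units; beyond the scatter) shows that the read-out responds to a change on the ring attached to the sulfonyl sulfur, here cyano on an aromatic carbon, meta to a large group. With nitro on an aromatic carbon, compound 3 gives > 10000 nM, which is a limit, so a new group on this ring does not always yield a number, and the steps among compound 1, compound 2 and compound 3 cannot be read. Compound 4 therefore gives the series its only number and its first sign of a position worth working on, set against a record otherwise made up of limits: the limit of > 10000 nM in this assay, at which 3 of the 4 values shown sit.

On these data alone, it remains open whether the response belongs to cyano itself or to its place, since a single compound cannot separate the two, and whether an amine, a carboxylic acid or a methyl ester on the same carbon would also give a number. As far as these compounds go, the true size of the step also remains open, since compound 2 is known only through a limit and the step therefore gives only a lower bound.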